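The source may hold more compounds than are shown below. What is called first, only, known or untested is meant among the compounds shown, and "the series" means these compounds.

Working notes on the series. Among the compounds with values here, compound 1 `Cc1cccc(NC[C@@H]2CC3(CC3)CN2C(=O)c2nc(C)sc2-c2ccccc2)n1` is the weaker of the two measured members: in a functional assay on CHO cells for antagonist activity at Orexin/Hypocretin receptor type 1 (Homo sapiens), read by FLIPR and calcium flux (a lower number here means a less potent compound, a higher number a more potent compound, by a factor of ten per unit of this negative logarithm), compound 1 gives 7.3. Compound 2 `O=C(c1cc(Cl)ccc1-c1ncccn1)N1CC2(CC2)C[C@H]1CNc1cc(C(F)(F)F)ccn1` stands highest of the two numbers, and in this assay compound 2 gives 8.1, a value that lies beyond the scatter above the nearest number, that of compound 1. Compound 3 `Cc1ccc(-c2ncccn2)c(C(=O)N2CC3(CC3)C[C@H]2CNc2cc(C(F)(F)F)ccn2)c1` has not yet been measured. It differs from compound 2 in one place: methyl in place of chloro on an aromatic carbon, so methyl in place of chloro on an aromatic carbon of a six-membered aromatic ring of carbon only, meta to a large group and para to a pyrimidin-2-yl group. Within the data shown here, no measured pair in the set shows what such an exchange does here. The step of a number 0.20 log units lower from compound 2 to compound 3 (within the scatter) is expected to be small, at most a modest loss and likely within the scatter. Compound 3 is therefore estimated at 7.9, with a range from 7.3 to 8.5.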

Compound 3, negative logarithm of the antagonist equilibrium constant: 7.3
Beside the measured number, compound 3's estimate is 0.60 log units above it; the measured number falls inside the stated range.
By their numbers in this assay, from the lowest: compounds 1 and 3 (each within the scatter of the next); then compound 2.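

On the aromatic carbon meta to a large group and para to a pyrimidin-2-yl group, replacing chloro with methyl in this assay gives a number 0.80 log units lower from compound 2 to compound 3 (beyond the scatter). Within the data shown here, this is the first one-place change, and it shows that this position responds to the exchange even though one heavy atom replaces one heavy atom, with no change in the counted hydrogen-bond donors, hydrogen-bond acceptors or net charge. Nothing measured here explains the difference between chloro and methyl at this position.

Still open, on these data alone, is where fluoro, methoxy or nitrile at this position would fall relative to chloro and methyl. As far as these compounds go, a single pair shows this exchange, so it also remains open whether a step of similar size would appear in a compound without the trifluoromethyl group.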